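Trimming the amine: from compound 2 to compound 4

A few compounds are considered here, and "the series" means these few. Any claim that something is new, unique, unknown or untested is made for them only; others in the source may bear on it.

Compound 1 `Cc1nnc(CN2CCCC2)n1-c1ccc(Cl)cc1C(O)c1ccccc1`: 8 mg/kg; 32 mg/kg (2 entries)
Compound 2 `Cc1nnc(CN2CCCC2)n1-c1ccc(Cl)cc1C(=O)c1ccccc1Cl`: 1.8 mg/kg
Compound 3 `Cc1nnc(CN2CCCC2)n1-c1ccc(Cl)cc1Cc1ccccc1`: 36 mg/kg

In a functional assay on the whole organism (strain CF-1) for inhibition, with Mus musculus as the target (a higher number here means that more compound is needed for the effect, a lower number that less compound is needed), compound 2 gives 1.8 mg/kg, the lower of the two single numbers in this set. Compound 3 gives 36 mg/kg, and the step of a 20-fold higher number from compound 2 to compound 3 (1.30 log units; beyond the scatter) is large. Compound 1 carries two entries the several entries of compound 1 in this assay, 8 mg/kg; 32 mg/kg (2 entries) rather than one number, which shows the spread such repeats can have.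

The next compound, compound 4 `Cc1nnc(CN(C)C)n1-c1ccc(Cl)cc1C(=O)c1ccccc1Cl`, differs from compound 2 in one place: dimethylamino in place of pyrrolidin-1-yl on a saturated chain carbon bound to an aromatic carbon. Among the measured compounds shown here, no measured step bears on this part of the molecule; the only measured step, from compound 2 to compound 3, changes the group on the aromatic carbon and leaves the amine untouched. For the measured compounds named here, the amine change therefore has no precedent here, and the expectation rests on the value of compound 2 alone. Compound 4 is expected to stay near compound 2, with a step of a 1.7-fold higher number from compound 2 to compound 4 (0.22 log units; within the scatter) that need not exceed the scatter. Compound 4 is thus estimated at 3 mg/kg, in a range from 1 mg/kg to 10 mg/kg.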

Compound 4, dose for half-maximal effect: 0.14 mg/kg
Compound 4: middle estimate off by 21-fold (1.33 log units), on the high side, and the stated range ends above it.
By their numbers in this assay, from the lowest: compound 4; then compound 2; then compound 3.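

The amine on the saturated chain carbon turns out to be a sensitive position in this assay: a 13-fold lower number from compound 2 to compound 4 (1.11 log units; beyond the scatter). Until now, only the group on the aromatic carbon had been shown to move the number, and this step is also large but runs towards less compound being needed. Compound 2 and compound 4 each rest on a single entry, and repeats in this assay can spread, as seen in: the several entries of compound 1 in this assay, 8 mg/kg; 32 mg/kg (2 entries).

The compounds shown leave open whether the lower number goes with losing the ring or with the smaller group, a question that diethylamino or azetidin-1-yl in the same place could help separate. They also leave open whether dimethylamino would have a similar effect with benzyl on the aromatic carbon.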